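A few compounds are considered here, and "the series" means these few. Any claim that something is new, unique, unknown or untested is made for them only; others in the source may bear on it.

Three members of the series carry a number in a functional assay on HepG2 cells (Homo sapiens) for antiproliferative activity, read by CCK-8 assay, with a stated time of 72 h; on this read-out higher numbers stand for weaker inhibition and lower numbers for stronger inhibition. Compound 1 `Cc1nc(C)c(/C=C/C(=O)c2ccc(NC(=O)c3ccccc3F)cc2)nc1C` gives 2040 nM, compound 2 `COc1ccc(C(=O)Nc2ccc(C(=O)/C=C/c3nc(C)c(C)nc3C)cc2)cc1OC` gives 2560 nM and compound 3 `Cc1nc(C)c(/C=C/C(=O)c2ccc(NC(=O)c3ccccc3)cc2)nc1C` gives 1310 nM. Compound 2 holds the highest of the three numbers, but the step of a 1.3-fold higher number from compound 1 to compound 2 (0.10 log units; within the scatter) and the step of a 2.0-fold lower number from compound 2 to compound 3 (0.29 log units; within the scatter) both stay within the scatter, so the three numbers sit together rather than in an order; the step of a 1.6-fold lower number from compound 1 to compound 3 (0.19 log units; within the scatter) also stays within the scatter.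

Compound 4 `COc1ccc(C(=O)Nc2ccc(C(=O)/C=C/c3nc(C)c(C)nc3C)cc2)cc1` differs from compound 2 by hydrogen in place of methoxy on an aromatic carbon. The group that leaves sits ortho to a methoxy group and meta to a large group; cut one bond further out, the change reads 3,4-dimethoxyphenyl to 4-methoxyphenyl.

The measured steps that touch the same aryl amide are a 1.3-fold higher number from compound 1 to compound 2 (0.10 log units; within the scatter) and a 2.0-fold lower number from compound 2 to compound 3 (0.29 log units; within the scatter). Among the measured compounds shown here, the second of these removes both methoxy groups at once and still stays within the scatter; removing only one is a smaller change. No step beyond the scatter is therefore expected in this assay, with a slight lean toward a lower number because a 2.0-fold lower number from compound 2 to compound 3 (0.29 log units; within the scatter). Compound 4 is expected to give 2000 nM, with a range from 1000 nM to 4000 nM. That expectation amounts to a 1.3-fold lower number from compound 2 to compound 4 (0.11 log units; within the scatter).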

Compound 4, half-maximal inhibitory concentration: 1190 nM
Compound 4: the middle estimate sits 1.7-fold (0.23 log units) above what was measured; the measured number falls inside the stated range.
By their numbers in this assay, from the lowest: compounds 4, 3, 1 and 2 (each within the scatter of the next, the first and the last beyond it).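

In this assay, among the compounds shown here, going from 3,4-dimethoxyphenyl to 4-methoxyphenyl gives a 2.2-fold lower number from compound 2 to compound 4 (0.33 log units; beyond the scatter), the only step so far to pass beyond the scatter, though it is modest; removing both methoxy groups at once gave a 2.0-fold lower number from compound 2 to compound 3 (0.29 log units; within the scatter), which stayed within it. The rest of the aryl amide set does not separate: the methoxy that remains on the ring gives a 1.1-fold lower number from compound 3 to compound 4 (0.04 log units; within the scatter), and 4-methoxyphenyl in place of 2-fluorophenyl gives a 1.7-fold lower number from compound 1 to compound 4 (0.23 log units; within the scatter), so compounds 1, 3 and 4 sit together and compound 2 stands apart only from compound 4. The separation rests on this single pair, and no independent data bear on why this change has this size.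

The compounds shown leave open whether a hydroxyl, an amino group or a longer ether such as ethoxy in the place of the departed methoxy would keep the number of compound 4 or return it toward that of compound 2. They also leave open whether a carboxylic acid or a dimethylamino group on this ring would produce any step beyond the scatter from compound 4.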